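The compounds below may be only part of what the source reports. "The series", "measured", "known", "first", "only" and "open" are said of these compounds alone.

Three closely related compounds share one core and have been tested in an ADME assay on MT4 cells (Homo sapiens) for cytotoxicity, read by MTT assay, with a stated time of 4 days; on this read-out higher numbers stand for lower toxicity in this test and lower numbers for higher toxicity in this test. Compound 1 `Cc1cc(-c2ccccc2)cc(C)c1Nc1ccnc(Nc2ccc(C#N)cc2)n1` carries a plain phenyl group and gives 4170 nM. Compound 2 `Cc1cc(-c2ccc(Cl)cc2)cc(C)c1Nc1ccnc(Nc2ccc(C#N)cc2)n1` gives 4190 nM. Compound 3 `Cc1cc(-c2ccccc2C(F)(F)F)cc(C)c1Nc1ccnc(Nc2ccc(C#N)cc2)n1` gives 4210 nM. Among the three numbers shown, compound 3 has nominally the top one, but the step of a 1.0-fold higher number from compound 1 to compound 3 (0.00 log units; within the scatter) and the step of a 1.0-fold higher number from compound 2 to compound 3 (0.00 log units; within the scatter) are both within the scatter, as is the step of a 1.0-fold higher number from compound 1 to compound 2 (0.00 log units; within the scatter), so the three compounds cannot be told apart in this assay.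

The next compound, compound 4 `Cc1cc(-c2cccc(F)c2)cc(C)c1Nc1ccnc(Nc2ccc(C#N)cc2)n1`, differs from compound 3 in a single place: 3-fluorophenyl in place of 2-(trifluoromethyl)phenyl on an aromatic carbon. The measured steps that bear on this change are the entry of a trifluoromethyl group, seen in the step from compound 1 to compound 3, and the swap of one substituted phenyl for another, seen in the step from compound 2 to compound 3; neither moved the number beyond the scatter. Since no change of this kind has shifted the read-out so far, compound 4 is expected to show a step of a 1.0-fold lower number from compound 3 to compound 4 (0.00 log units; within the scatter) in this assay, that is, nothing beyond the scatter. The estimate for compound 4 is therefore 4200 nM, with a range from 2100 nM to 8400 nM.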

Compound 4, half-maximal cytotoxic concentration: 4120 nM
Estimate against measurement, compound 4: 1.0-fold (0.01 log units) above, and the stated range covers the measured number.
By their numbers in this assay, from the lowest: compounds 4, 1, 2 and 3 (each within the scatter of the next).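

The position meta to two methyl groups has now held a third kind of substituted phenyl, and in this assay placing fluoro on the plain phenyl gives a 1.0-fold lower number from compound 1 to compound 4 (0.01 log units; within the scatter). Trading 2-(trifluoromethyl)phenyl for 3-fluorophenyl gives a 1.0-fold lower number from compound 3 to compound 4 (0.01 log units; within the scatter), and trading 4-chlorophenyl for 3-fluorophenyl gives a 1.0-fold lower number from compound 2 to compound 4 (0.01 log units; within the scatter), so across these four compounds neither the halogen-bearing group on the phenyl ring nor the place it occupies, as given by these group names, separates one compound from another in this test. Nothing measured here offers an explanation for why the read-out stays within the scatter across these changes.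

Every group shown at this position is a phenyl ring carrying either no substituent or a single group containing a halogen, so it remains open whether an amine, a carboxylic acid or a hydroxyl group on that ring would leave the read-out just as unchanged. As far as these compounds go, it also remains open whether replacing the phenyl ring itself with a saturated ring or a longer carbon chain, or changing the nitrile elsewhere on the shared core, would move the number beyond the scatter.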